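Amino in Place of Hydroxymethyl: What Compound 4 May Show

A few compounds are considered here, and "the series" means these few. Any claim that something is new, unique, unknown or untested is made for them only; others in the source may bear on it.

Measured so far in an ADME assay on the whole organism (serum) with Homo sapiens as the target; on this read-out lower numbers stand for a shorter-lived compound and higher numbers for a longer-lived compound:
Compound 1, `Cc1cn(C2CC(N=[N+]=[N-])C(COC(=O)NCCCC(=O)OC(C)(C)C)O2)c(=O)[nH]c1=O`: > 48 h, a limit of the assay rather than a number.
Compound 2, `Cc1cn(C2CC(N=[N+]=[N-])C(COC(=O)OCCCCO)O2)c(=O)[nH]c1=O`: 0.5 h.
Compound 3, `Cc1cn(C2CC(N=[N+]=[N-])C(COC(=O)OCCCCCCO)O2)c(=O)[nH]c1=O`: 0.117 h.

Among the two real numbers, compound 2 stands highest, with compound 3 nearest; the one measured step is a 4.3-fold lower number from compound 2 to compound 3 (0.63 log units; beyond the scatter). Among the compounds with values here, the remaining value, that of compound 1, sits at the limit of > 48 h in this assay, at which 1 of the 3 values shown sits, and says only that the compound outlasted the assay window.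

Compound 4, `Cc1cn(C2CC(N=[N+]=[N-])C(COC(=O)OCCCN)O2)c(=O)[nH]c1=O`, is still to be measured. It differs from compound 2 by amino in place of hydroxymethyl on a saturated chain carbon, three bonds along the chain from an oxygen next to a carbonyl group. Within the data shown here, the single measured step, from compound 2 to compound 3, lengthened the same chain and lowered the half-life by a modest amount; the change to compound 4 instead shortens the chain by one heavy atom and exchanges oxygen for nitrogen at its end. Among the measured compounds shown here, no measured pair contains an amino group, so there is nothing that fixes a direction for this exchange. The expectation is therefore a step near or within the scatter: a 1.3-fold lower number from compound 2 to compound 4 (0.10 log units; within the scatter) is the estimated change. Compound 4 is expected to give about 0.4 h in this assay, between 0.1 h and 1.6 h.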

Compound 4, half-life: 0.133 h
For compound 4 the middle estimate is 3.0-fold (0.48 log units) above the measured one; measured number inside the range.
By their numbers in this assay, from the lowest: compounds 3 and 4 (each within the scatter of the next); then compound 2. At a limit, above all of these: compound 1.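

In this assay, the exchange of hydroxymethyl for amino at this place on the chain is not neutral: the result is a 3.8-fold lower number from compound 2 to compound 4 (0.58 log units; beyond the scatter), a modest step and the only one shown that involves an amino group. Set against the other short-lived compound, the result is a 1.1-fold higher number from compound 3 to compound 4 (0.06 log units; within the scatter), so these two compounds cannot be told apart on this read-out even though their chains differ in length and in the group at the end. Compound 2 therefore stands apart from both compound 3 and compound 4, and two different changes to its chain end, a longer chain with the hydroxy group kept and the amino exchange, each give a number beyond the scatter from it.

Nothing given here explains why either change shortens the half-life. This exchange also shortens the chain, so the step cannot be split between the amino group and the chain length, and a longer chain ending in an amine, or a carboxylic acid at the chain end, would show how much depends on each.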